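A few compounds are considered here, and "the series" means these few. Any claim that something is new, unique, unknown or untested is made for them only; others in the source may bear on it.

Compound 1 `COc1cc(C2CC(c3ccc(Br)cc3)=NN2C(C)=O)ccc1OCc1cn(Cc2ccc([N+](=O)[O-])cc2)nn1` and compound 2 `COc1ccc(C2=NN(C(C)=O)C(c3ccc(OCc4cn(Cc5ccc([N+](=O)[O-])cc5)nn4)c(OC)c3)C2)cc1` share one core and differ at a single aromatic carbon. In a functional assay on THP-1 cells (Homo sapiens) for inhibition, read by sulforhodamine B assay, tested at 100 uM (on this read-out higher numbers stand for more inhibition of growth at the one concentration tested and lower numbers for less inhibition of growth), compound 1 gives 23%, and compound 2 gives 14%. The one measured step, a number 9 percentage points lower from compound 1 to compound 2 (within the scatter), puts methoxy in place of bromo on an aromatic carbon and stays within the scatter, so on the numbers shown compound 2 stands alongside compound 1 rather than apart from it. Compound 3 `COc1cc(C2CC(c3cc(OC)c(OC)c(OC)c3)=NN2C(C)=O)ccc1OCc1cn(Cc2ccc([N+](=O)[O-])cc2)nn1` has not been measured. It differs from compound 2 by 3,4,5-trimethoxyphenyl in place of 4-methoxyphenyl on a carbon with a double bond to nitrogen. Among the compounds with values here, no measured step bears on this change: the single known step concerns another group at another place, and it was small. The account therefore expects no step beyond the scatter, a number 3 percentage points higher from compound 2 to compound 3 (within the scatter). For compound 3 the estimate in this assay is 17%, with a range from 0% to 38%.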

Compound 3, percent growth inhibition at one concentration: 43%
Compound 3: middle estimate off by 26 percentage points, on the low side; measured number outside the range, above it.
By their numbers in this assay, from the lowest: compounds 2 and 1 (each within the scatter of the next); then compound 3.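

With the aryl group on the carbon with a double bond to nitrogen, this assay gives a clearer picture: 3,4,5-trimethoxyphenyl in place of 4-methoxyphenyl gives a number 29 percentage points higher from compound 2 to compound 3 (beyond the scatter) and in place of 4-bromophenyl gives a number 20 percentage points higher from compound 1 to compound 3 (beyond the scatter) as well. Within the data shown here, the earlier pair, with methoxy in place of bromo, had stayed within the scatter, so this is the first sign that the group at this position can change growth inhibition at the one concentration tested. Nothing available explains why the 3,4,5-trimethoxyphenyl group stands apart here.

From the compounds shown here alone, it remains open how much of this difference belongs to any single methoxy of the 3,4,5-trimethoxyphenyl group. Going by these compounds, it is also open whether an amine or a carboxylic acid on this phenyl ring would give a number nearer that of compound 3 or nearer those of compound 1 and compound 2.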